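The source may report more compounds than this note shows. Statements on the series, on what has been measured and on what is new or still open speak of the compounds shown alone.

Measured compounds in a functional assay on SK-MEL-2 cells (Homo sapiens) for inhibition, read by sulforhodamine B assay, with a stated time of 48 h; on this read-out higher numbers stand for lower toxicity in this test and lower numbers for higher toxicity in this test:
compound 1 `CCOC(=O)[C@H](CCC(=O)O)NC(=O)c1ccc(Sc2nc3cc(N)cc(N)c3nc2-c2ccccc2)cc1` — < 100000 nM
compound 2 `Nc1cc(N)c2nc(-c3ccccc3)c(Sc3ccc(F)cc3)nc2c1` — < 100000 nM
compound 3 `COc1cc(CNc2nc3cc(N)cc(N)c3nc2-c2ccccc2)cc(OC)c1OC` — < 50200 nM

Every one of these three results is a limit of the assay and not a number. For compound 1 the result in this assay is the limit < 100000 nM. Compound 2 likewise gives only the limit < 100000 nM in this assay. Compound 3 stops at the limit < 50200 nM in this assay. Among the compounds with values here, compound 2 therefore stands at the limit of < 100000 nM in this assay, at which 2 of the 3 values shown sit, while compound 3 sits at the limit of < 50200 nM in this assay, at which 1 of the 3 values shown sits; with limits alone, no order among the three compounds can be read, and no step between measured compounds is available.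

Compound 4 `Nc1cc(N)c2nc(-c3ccccc3)c(NCc3ccc(F)cc3)nc2c1` has not yet been measured. It differs from compound 2 in one place: (4-fluorobenzyl)amino in place of (4-fluorophenyl)sulfanyl on an aromatic carbon. With only limits behind compound 2, a step from compound 2 to compound 4 no larger than the usual scatter is expected, a step that the limit leaves unreadable from compound 2 to compound 4. Compound 4 is estimated at 60000 nM in this assay, within 20000 nM to 100000 nM, and it is expected that the assay will again report only a limit.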

Compound 4, concentration lethal to 50% of the cells: < 100000 nM
Compound 4 ended at the assay's limit; the forecaster's own chance of this, stated with the estimate: 85%; the middle value lies beyond the limit too.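

Compound 2 and compound 4 each give only a limit of the assay, and the step between them cannot be read. The compounds shown leave open whether (4-fluorobenzyl)amino in place of (4-fluorophenyl)sulfanyl changes toxicity in this test at all, and what any compound's actual value is.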